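The compounds below may be only part of what the source reports. "The series", "measured", "known", "first", "only" and "open" are said of these compounds alone.

Measured so far in a functional assay on HeLa cells (Homo sapiens) for antiproliferative activity, read by sulforhodamine B assay, with a stated time of 72 h; a lower number here means a stronger inhibitor, a higher number a weaker inhibitor:
compound 1 `FC(F)(F)c1ccc(/C=C\c2cc3ccc(Cl)cc3nc2Cl)cc1` gives 12600 nM;
compound 2 `Fc1ccc(/C=C\c2cc3ccc(Cl)cc3nc2Cl)cc1` gives 38600 nM;
compound 3 `COc1ccc2nc(Cl)c(/C=C\c3ccc(C(F)(F)F)cc3)cc2c1` gives 16200 nM.

Compound 1 and compound 2 differ in one place: fluoro in place of trifluoromethyl on an aromatic carbon. That single change gave a 3.1-fold higher number from compound 1 to compound 2 (0.49 log units; beyond the scatter). Compound 3 carries a different core; how its core differs from that of compound 1 is not broken down here. Compound 4 `COc1ccc2nc(Cl)c(/C=C\c3ccc(F)cc3)cc2c1` awaits measurement in this assay and differs from compound 3 by exactly this change: fluoro in place of trifluoromethyl on an aromatic carbon. The surroundings of the changed position are described in the same words in both pairs, so the change counts as the same one. Compound 4 is therefore expected to show a 3.0-fold higher number from compound 3 to compound 4 (0.47 log units; beyond the scatter), a step of about the size seen before, because the same change gave a 3.1-fold higher number from compound 1 to compound 2 (0.49 log units; beyond the scatter). Compound 4 is estimated at 48000 nM, likely between 22000 nM and 110000 nM.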

Compound 4, half-maximal inhibitory concentration: 9670 nM
The estimate for compound 4 lay 5.0-fold (0.70 log units) above the measured number; measured number outside the range, below it.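

In this assay, the swap from trifluoromethyl to fluoro on the methoxy-bearing core gave a 1.7-fold lower number from compound 3 to compound 4 (0.22 log units; within the scatter), so this pair cannot be told apart by this measurement. The step seen on one core therefore did not carry over to the other, and the two cores must be read separately for this change: the same change on two cores in this assay, a 3.1-fold higher number (0.49 log units; beyond the scatter) from compound 1 to compound 2 and a 1.7-fold lower number (0.22 log units; within the scatter) from compound 3 to compound 4, 5.1-fold (0.71 log units) apart, beyond the scatter of two such steps

These two pairs do not show why the cores differ, nor which result would be more typical on further cores in this series.

The compounds shown leave open how a different group in the same place, such as an amine or a carboxylic acid, would behave on each core. They also leave open whether any such group would give the same step on both.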